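Dropping the Isopropyl Ester from the Distal Phenyl Amide

A few compounds are considered here, and "the series" means these few. Any claim that something is new, unique, unknown or untested is made for them only; others in the source may bear on it.

In an assay on cells for inhibition of Rho-associated protein kinase 2 (Homo sapiens), read by radiometric assay and 33P incorporation, in the presence of a further agent that is not named here (a lower number here means a stronger inhibitor, a higher number a weaker inhibitor), compound 3 `CC(C)OC(=O)c1cccc(NC(=O)c2cccc(-c3cc(C(=O)Nc4ccncc4F)ccc3CN)c2)c1` gives 7 nM, the highest number of the three measured analogues; compound 1 `NCc1ccc(C(=O)Nc2ccncc2F)cc1-c1cccc(C(=O)Nc2cccc(CC(=O)O)c2)c1` gives 1.5 nM and compound 2 `NCc1ccc(C(=O)Nc2ccncc2F)cc1-c1cccc(C(=O)Nc2ccc(CC(=O)O)cc2)c1` gives 1.8 nM in this assay. a 1.2-fold higher number from compound 1 to compound 2 (0.08 log units; within the scatter) lies within the scatter, whereas a 4.7-fold higher number from compound 1 to compound 3 (0.67 log units; beyond the scatter) and a 3.9-fold higher number from compound 2 to compound 3 (0.59 log units; beyond the scatter) are modest but beyond it. Compound 4 `NCc1ccc(C(=O)Nc2ccncc2F)cc1-c1cccc(C(=O)Nc2ccccc2)c1` differs from compound 3 by hydrogen in place of isopropoxycarbonyl on an aromatic carbon. Among the compounds with values here, the two measured steps into compound 3 show that exchanging the group on this aromatic carbon shifts the number only modestly, and no measured step removes that group altogether. Therefore only a small step is expected: a 1.4-fold lower number from compound 3 to compound 4 (0.15 log units; within the scatter). The estimate for compound 4 in this assay is 5 nM, ranging from 1.5 nM to 20 nM.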

Compound 4, half-maximal inhibitory concentration: < 1 nM
Compound 4 gave a limit, no number; the forecaster's own chance of this, stated with the estimate: 2%; middle value at least 5.0-fold (0.69 log units) from the limit.
By their numbers in this assay, from the lowest: compounds 1 and 2 (each within the scatter of the next); then compound 3. At a limit, below all of these: compound 4.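

Compound 4 gave a limit and not a number: the limit of < 1 nM in this assay, at which 1 of the 4 values shown sits. With hydrogen in place of isopropoxycarbonyl the step is an at least 7.0-fold lower number from compound 3 to compound 4 (0.84 log units; beyond the scatter), so this position needs no group at all for a low number, and the ester is not needed. Set against the carboxymethyl compounds, the steps are an at least 1.8-fold lower number from compound 2 to compound 4 (0.25 log units; that floor lies within the scatter) and an at least 1.5-fold lower number from compound 1 to compound 4 (0.17 log units; that floor lies within the scatter), and with those floors within the scatter, hydrogen cannot be ranked apart from carboxymethyl.

As far as these compounds go, how far the true value of compound 4 lies past its limit stays open. So does whether an amine or a carboxylic acid set directly on this ring would hold the number as low.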